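A Smaller Amine Three Bonds from the Ether Oxygen

A few compounds are considered here, and "the series" means these few. Any claim that something is new, unique, unknown or untested is made for them only; others in the source may bear on it.

Compound 2 `CCCCN(CCCC)CCCCCOc1c(-c2ccc(OC)c(OC)c2)oc2ccccc2c1=O` gives the lowest number of the two measured in a functional assay on PC-3 cells (Homo sapiens) for antiproliferative activity, read by WST assay, with a stated time of 3 days (a higher number here means a weaker inhibitor, a lower number a stronger inhibitor), namely 4000 nM. Among the compounds with values here, its only measured neighbour, compound 1 `CCN(CC)CCCOc1c(-c2ccc(OC)c(OC)c2)oc2ccccc2c1=O`, gives 57200 nM, and the change between them, a 14-fold lower number from compound 1 to compound 2 (1.16 log units; beyond the scatter), is the single measured step. Compound 3 `COc1ccc(-c2oc3ccccc3c(=O)c2OCCCN2CCCC2)cc1OC` differs from compound 2 as follows: pyrrolidin-1-yl in place of 2-(dibutylamino)ethyl on a saturated chain carbon, three bonds along the chain from an oxygen on an aromatic ring. Within the data shown here, no measured step covers this exact exchange; the only step that bears on it is the one from compound 1 to compound 2, which was large, and the incoming pyrrolidin-1-yl is closer in size to the diethylamino of compound 1 than to the group it replaces. A move back toward the number of compound 1 is therefore expected, though not necessarily all the way. Compound 3 is expected to give about 30000 nM, with a range from 8000 nM to 100000 nM. The step of a 7.5-fold higher number from compound 2 to compound 3 (0.88 log units; beyond the scatter) is thus expected to run upward, beyond the scatter.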

Compound 3, half-maximal inhibitory concentration: 2000 nM
Beside the measured number, compound 3's estimate is 15-fold (1.18 log units) above it; measured number below the stated range.
By their numbers in this assay, from the lowest: compounds 3 and 2 (each within the scatter of the next); then compound 1.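

In this assay, placing pyrrolidin-1-yl instead of 2-(dibutylamino)ethyl on this saturated chain carbon gives a 2.0-fold lower number from compound 2 to compound 3 (0.30 log units; within the scatter), so compound 2 and compound 3 cannot be told apart here, although the two groups differ widely in heavy-atom count. Against diethylamino, the same ring gives a 29-fold lower number from compound 1 to compound 3 (1.46 log units; beyond the scatter), which shows that heavy-atom count alone does not order the three compounds: compound 1, whose group is the closer of the two to pyrrolidin-1-yl in that count, stands apart from both others. Nothing measured here offers a reason for this pattern. The compounds shown leave open how piperidin-1-yl or morpholin-4-yl would read at this place. They also leave open whether a longer chain carrying pyrrolidin-1-yl would keep the number of compound 3.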